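The source may hold more compounds than are shown below. What is called first, only, known or untested is meant among the compounds shown, and "the series" means these compounds.

Compound 1 `COc1cccc2c1c(NS(=O)(=O)c1ccc(Cl)s1)nn2Cc1cccc(CNC(=O)C2CCCO2)c1`: in a physicochemical assay for solubility, read by chemiluminescence, measured as kinetic solubility (a lower number here means a less soluble compound, a higher number a more soluble compound), compound 1 gives >= 153 ug/mL, which is a limit of the assay rather than a number.
Compound 2 `COc1cccc2c1c(NS(=O)(=O)c1ccc(Cl)s1)nn2Cc1cccc(CNC(=O)C2CCOCC2)c1`: in this assay compound 2 gives >= 193 ug/mL, again a limit and not a number.

Going by the values given here, compound 2 therefore stands at a limit in this assay, and the other value shown is a limit too (the limit of >= 153 ug/mL in this assay, at which 1 of the 2 values shown sits, (the limit of >= 193 ug/mL in this assay, at which 1 of the 2 values shown sits)), so the only measured step, a step that the two limits leave unreadable from compound 1 to compound 2, cannot be read. Compound 3 `CN[C@H](C)C(=O)NCc1cccc(Cn2nc(NS(=O)(=O)c3ccc(Cl)s3)c3c(OC)cccc32)c1` differs from compound 2 by 1-(methylamino)ethyl in place of oxan-4-yl on a carbonyl carbon. Among the compounds with values here, no readable step bears on this change; the one step from compound 1 to compound 2 gives no size. With compound 2 sitting at a limit in this assay, compound 3 is expected to remain in the same high region, and the value of compound 3 is estimated at 200 ug/mL, between 100 ug/mL and 350 ug/mL. This corresponds to an expected step that the limit leaves unreadable from compound 2 to compound 3, not beyond the scatter.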

Compound 3, solubility: 191 ug/mL
Compound 3: the middle estimate sits 1.0-fold (0.02 log units) above what was measured; the measured number falls inside the stated range.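

In this assay compound 3 gives 191 ug/mL, the only number rather than a limit among the compounds shown, so this place on the carbonyl carbon now has one measured value, carried by an open chain with no ring, 1-(methylamino)ethyl. Compound 2 gives >= 193 ug/mL, which is a limit of the assay and not a number. Set against that limit, the result is a number no higher from compound 2 to compound 3 (the limit leaves the size open). The step to compound 3 from compound 1 cannot be read, because it rests on a limit: the limit of >= 153 ug/mL in this assay, at which 1 of the 3 values shown sits.

Open, as far as these compounds go, is whether a plain ethyl chain without the nitrogen, or a carboxylic acid, on the same carbonyl carbon would give a value of this order. Open too, from the compounds shown here alone, is whether the mirror-image form of 1-(methylamino)ethyl would read alike.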